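The source may hold more compounds than are shown below. What is called first, only, known or untested is meant among the compounds shown, and "the series" means these compounds.

Measured compounds:
- compound 1 `CCC(=O)Nc1ccc(Nc2cccc(OC)c2)cc1` — 1.8 nM
- compound 2 `COc1cccc(Nc2ccc(NC(=O)C(C)C)cc2)c1` — 84 nM

In an assay on isolated protein for binding affinity to melatonin receptor type 1B (Homo sapiens) (a lower number here means a stronger inhibitor, a higher number a weaker inhibitor), compound 2 gives 84 nM, the highest of the two numbers recorded, and thus the weaker binder of the pair. Among the compounds with values here, the only measured step, a 47-fold higher number from compound 1 to compound 2 (1.67 log units; beyond the scatter), shows how much a small enlargement of the acyl group beside the amide can cost. Compound 3 `COc1cccc(Nc2ccc(NC(=O)C3CC3)cc2)c1` is not yet measured. It differs from compound 2 in one place: cyclopropyl in place of isopropyl on a carbonyl carbon. Both groups share the same count of carbon atoms, yet the cyclopropyl closes them into a ring. Within the data shown here, the step of a 47-fold higher number from compound 1 to compound 2 (1.67 log units; beyond the scatter) is the only guide, and it speaks to a different change; it suggests the acyl group is sensitive, so a shape between that of compound 1 and compound 2 is expected to land between them. Compound 3 is therefore expected to give 20 nM in this assay, between 5 nM and 80 nM, which means an expected step of a 4.2-fold lower number from compound 2 to compound 3 (0.62 log units; beyond the scatter).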

Compound 3, inhibition constant: 64 nM
Compound 3: middle estimate off by 3.2-fold (0.51 log units), on the low side, and the stated range covers the measured number.
By their numbers in this assay, from the lowest: compound 1; then compounds 3 and 2 (each within the scatter of the next).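

In this assay, closing isopropyl into cyclopropyl on the carbonyl carbon makes no clear difference, with a 1.3-fold lower number from compound 2 to compound 3 (0.12 log units; within the scatter). The branched group and the ring have the same count of carbon atoms, so tying the ends of the group into a ring does not by itself bring the number back towards that of the ethyl compound, and ethyl remains well apart from the ring, with a 36-fold higher number from compound 1 to compound 3 (1.55 log units; beyond the scatter). Among these three compounds, ethyl gives the clearly lowest number, while isopropyl and cyclopropyl cannot be told apart.

Nothing available explains why the two larger groups read alike or why both differ from ethyl. As far as these compounds go, how a longer chain such as propyl or a larger ring such as cyclobutyl would read on this carbonyl carbon stays open.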